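Allyl to phenyl on compound 2

The compounds below may be only part of what the source reports. "The series", "measured", "known", "first", "only" and "open" are said of these compounds alone.

Values in an ADME assay on J774 cells (Mus musculus) for cytotoxicity, read by MTT assay, with a stated time of 48 h; a higher number here means a weaker inhibitor, a lower number a stronger inhibitor:
Compound 1 `NC(=S)N/N=C\c1ccccc1OCc1ccc2no[n+]([O-])c2c1`: < 100 uM (a limit)
Compound 2 `C=CCNC(=S)N/N=C\c1ccccc1OCc1ccc2no[n+]([O-])c2c1`: 138 uM

In this assay, among the measured compounds shown here, compound 2 gives 138 uM, the only exact number so far. Compound 1 gives < 100 uM, which is a limit. For the measured compounds named here, the one measured step at this nitrogen is an at least 1.3-fold higher number from compound 1 to compound 2 (0.13 log units; that floor lies within the scatter). It offers a floor and no true size.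

Compound 3 `[O-][n+]1onc2ccc(COc3ccccc3/C=N\NC(=S)Nc3ccccc3)cc21` carries phenyl in place of allyl on an amide-type nitrogen. With so little to go on, no change beyond the scatter is expected, and the estimated change is a 1.3-fold lower number from compound 2 to compound 3 (0.10 log units; within the scatter). The estimate for compound 3 is 110 uM, with an expected range of 40 uM to 280 uM.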

Compound 3, concentration for 50% inhibition: > 400 uM
Compound 3 ended at the assay's limit; the forecaster's own chance of this, stated with the estimate: 20%; middle value at least 3.6-fold (0.56 log units) away from the limit.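

In this assay, this amide-type nitrogen now shows a step beyond the scatter: phenyl in place of allyl gives an at least 2.8-fold higher number from compound 2 to compound 3 (0.46 log units; beyond the scatter). Phenyl in place of hydrogen gives an at least 4.0-fold higher number from compound 1 to compound 3 (0.60 log units; beyond the scatter), while the earlier allyl step offered only a floor within the scatter. Compound 3 gives > 400 uM, which is a limit, and both new steps are floors, not true sizes.

Going by these compounds, how a saturated ring such as cyclohexyl or a longer chain such as butyl would read on this nitrogen stays open, as does the true size of the phenyl step.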